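Replacing the cyano group of compound 2

The source may report more compounds than this note shows. Statements on the series, on what has been measured and on what is new or still open speak of the compounds shown alone.

Compound 1 `COCCOCn1c(Br)c(C#N)c2c(N)ncnc21`: > 100000 nM
Compound 2 `COCCOCn1cc(C#N)c2c(N)ncnc21`: > 100000 nM

In a functional assay on KB cells (Homo sapiens) for inhibition (a higher number here means a weaker inhibitor, a lower number a stronger inhibitor), compound 2 stands at > 100000 nM, which is a limit and not a number. Compound 3 `COCCOCn1cc(C(N)=S)c2c(N)ncnc21` differs from it as follows: a group of 3 heavy atoms (1 carbon, 1 nitrogen, 1 sulfur; no ring) in place of a group of 2 heavy atoms (1 carbon, 1 nitrogen; no ring), on an aromatic carbon. The change lies on an aromatic carbon of a five-membered aromatic ring. Among the compounds with values here, the one measured step is a step that the two limits leave unreadable from compound 1 to compound 2, and it does not touch the cyano group. Within the data shown here, the only other evidence is the limit of > 100000 nM in this assay, at which 2 of the 2 values shown sit. Neither gives a size to carry over, so only a cautious move towards stronger inhibition is expected. The estimated step is an at least 2.0-fold lower number from compound 2 to compound 3 (0.30 log units; that floor lies within the scatter). For compound 3 the expected value is 50000 nM, with an estimated range of 5000 nM to 100000 nM.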

Compound 3, half-maximal inhibitory concentration: 183000 nM
Compound 3: the middle estimate sits 3.7-fold (0.56 log units) below what was measured; the measured number lies above the stated range.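

The step from compound 2 to compound 3 cannot be read: compound 2 stands at a limit, > 100000 nM, and not at a number. What the cyano group itself contributes in this assay stays open with the compounds shown.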